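The source may report more compounds than this note shows. Statements on the series, on what has been measured and on what is new or still open speak of the compounds shown alone.

Compound 1 `CN(Cc1ncnc2c1ncn2[C@@H]1O[C@H](CO)[C@@H](O)[C@H]1O)c1ccccc1` is tested in a functional assay on Huh-7 cells (Homo sapiens) for cytotoxicity, read by MTT assay, with a stated time of 3 days (a higher number here means that more compound is tolerated, a lower number that less compound is tolerated), where compound 1 gives 21000 nM. Compound 3 `CC(C)N(Cc1ncnc2c1ncn2[C@@H]1O[C@H](CO)[C@@H](O)[C@H]1O)C(C)C` gives 18000 nM in this assay, and the step of a 1.2-fold lower number from compound 1 to compound 3 (0.07 log units; within the scatter) shows that these two sit within the scatter of each other. Compound 2 `OC[C@H]1O[C@@H](n2cnc3c(Cn4cccn4)ncnc32)[C@H](O)[C@@H]1O` reaches only a limit of this assay, > 250000 nM. This is the one such case: the limit of > 250000 nM in this assay, at which 1 of the 3 values shown sits. Compound 4 `O=c1ccccn1Cc1ncnc2c1ncn2[C@@H]1O[C@H](CO)[C@@H](O)[C@H]1O` is not yet measured; it differs from compound 1 by a group of 7 heavy atoms (5 carbon, 1 nitrogen, 1 oxygen; one six-membered aromatic ring with 1 hetero atom) in place of a group of 8 heavy atoms (7 carbon, 1 nitrogen; one six-membered aromatic ring of carbon only), on a saturated chain carbon bound to an aromatic carbon. For the measured compounds named here, the steps that bear on this change are an at least 11-fold higher number from compound 1 to compound 2 (1.07 log units; beyond the scatter) and an at least 13-fold lower number from compound 2 to compound 3 (1.14 log units; beyond the scatter), both large, each involving an aromatic ring joined through its nitrogen in place of an amino group; the step of a 1.2-fold lower number from compound 1 to compound 3 (0.07 log units; within the scatter), an exchange of one amino group for another, stayed within the scatter. Compound 4, like compound 2, carries an aromatic ring joined through its nitrogen, so a larger tolerated amount is expected, by a 4.8-fold higher number from compound 1 to compound 4 (0.68 log units; beyond the scatter). Compound 4 is therefore estimated at 100000 nM, with a range from 30000 nM to 250000 nM, and a limit rather than a number is possible.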

Compound 4, half-maximal cytotoxic concentration: > 100000 nM
Compound 4 ended at the assay's limit (the forecaster's own chance of this, stated with the estimate: 35%); the middle value sits exactly at the limit.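

Compound 4 shows that in this assay the rise in tolerated amount at this place is not confined to the five-membered ring of compound 2, since a six-membered aromatic ring with 1 hetero atom, joined through its nitrogen, also gives an at least 4.7-fold higher number from compound 1 to compound 4 (0.67 log units; beyond the scatter) and an at least 5.5-fold higher number from compound 3 to compound 4 (0.74 log units; beyond the scatter). Both steps are beyond the scatter and give only a minimum size, as compound 4 stops at a limit and not at a number: the limit of > 100000 nM in this assay, at which 1 of the 4 values shown sits. The step between compound 2 and compound 4 cannot be read, so the two ring groups cannot be placed in order.

As far as these compounds go, it remains open whether a ring joined through a nitrogen is what matters, or whether a phenyl ring joined through carbon would do the same. A saturated ring amine such as morpholine at this place would show whether amino groups as a whole stay with compound 1 and compound 3.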